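This account rests on a few compounds, and the source may have more. Where it says the series, first, only, none or still open, it means among the compounds named here.

Measured so far in a functional assay on MCF7 cells (Homo sapiens) for antiproliferative activity, read by MTT assay; on this read-out lower numbers stand for stronger inhibition and higher numbers for weaker inhibition:
Compound 1 `CC/C=C\C/C=C\C/C=C\CCCCCCCc1cc(=O)c2c(O)c(C)c(O)c(C)c2o1`: 17500 nM
Compound 2 `CCCCC/C=C\C/C=C\CCCCCCCc1cc(=O)c2c(O)c(C)c(O)cc2o1`: > 84100 nM (a limit, not a number)

Compound 2 has no numerical value in this assay, and its > 84100 nM is a limit of the assay.

Compound 3 `CCCCC/C=C\C/C=C\CCCCCCCc1cc(=O)c2c(O)c(C)c(O)c(C)c2o1` comes from compound 2 through a single change: methyl in place of hydrogen on an aromatic carbon. For the measured compounds named here, no measured pair isolates this change, so the expected size of the step is an inference rather than a reading. Going by the values given here, the only guide is compound 1 at 17500 nM, which has the same core as compound 3 but a different side chain. Compound 3 keeps the side chain of compound 2, so the range has to stay wide, and a second result at the limit cannot be ruled out.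

The expected direction in this assay is towards stronger inhibition, by a step beyond the scatter. The estimated step is an at least 3.3-fold lower number from compound 2 to compound 3 (0.52 log units; beyond the scatter). For compound 3 the expected value is 25000 nM, with an estimated range of 10000 nM to 70000 nM.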

Compound 3, half-maximal inhibitory concentration: > 84100 nM
Compound 3 gave a limit, no number (the forecaster's own chance of this, stated with the estimate: 20%); middle value at least 3.3-fold (0.52 log units) away from the limit.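

In this assay compound 3 gives > 84100 nM, which is a limit and not a number. The step for methyl in place of hydrogen on the aromatic carbon, ortho to a fused ring and para to a hydroxy group, therefore cannot be read, and this methyl does not bring the side chain of compound 2 off the limit: the limit of > 84100 nM in this assay, at which 2 of the 3 values shown sit.

For the compounds shown here, the one readable comparison now concerns the side chain rather than the ring position: with the core of compound 1 held constant, butyl in place of but-1-en-1-yl on a saturated chain carbon bound to a double-bonded chain carbon gives an at least 4.8-fold higher number from compound 1 to compound 3 (0.68 log units; beyond the scatter), a change beyond the usual scatter.

The compounds shown leave open whether methyl in place of hydrogen at this position changes the number at all, a question that a pair on the side chain of compound 1 could answer. They also leave open how an ethyl group in place of this methyl, or a shorter chain in place of the side chain, would stand in this assay.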